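Swapping the charged ring end of a long ether chain

The source may report more compounds than this note shows. Statements on the series, on what has been measured and on what is new or still open speak of the compounds shown alone.

Compound 1 `Cc1cc(-n2cc(C(=O)Nc3cc(F)cc(F)c3)c(=O)c3ccc(N(C)C)nc32)ccc1OCCCCCCC[N+]1(C)CCCCC1` is a charged, long-chain amide. In an assay on LX2 cells for inhibition of COL1A1 promoter (Homo sapiens), read by a luciferase reporter, with a stated time of 24 h, tested at 50 uM (on this read-out higher numbers stand for a stronger effect at the one concentration tested and lower numbers for a weaker effect), compound 1 gives 54.4%. Compound 3 `Cc1cc(-n2cc(C(=O)Nc3cc(F)cc(F)c3)c(=O)c3ccc(N(C)C)nc32)ccc1OCCCCCCC[n+]1ccccc1` differs from it by one change, (a group of 6 heavy atoms (5 carbon, 1 nitrogen; one six-membered aromatic ring with 1 hetero atom) in place of a group of 7 heavy atoms (6 carbon, 1 nitrogen; one six-membered non-aromatic ring with 1 hetero atom), on a saturated chain carbon, seven bonds along the chain from an oxygen on an aromatic ring). In this assay compound 3 gives 55%, so the step is a number 0.6 percentage points higher from compound 1 to compound 3 (within the scatter). Compound 2 `Cc1cc(OCCCCCCC[N+]2(C)CCCCC2)cc(-n2cc(C(=O)Nc3cc(F)cc(F)c3)c(=O)c3ccc(N(C)C)nc32)c1` shares the same atoms with compound 1 joined differently; the difference between the two cores is not broken down here. In this assay compound 2 gives 79.7%, the highest of the three numbers, beyond the scatter from both compound 1 and compound 3. Compound 4 `Cc1cc(OCCCCCCC[n+]2ccccc2)cc(-n2cc(C(=O)Nc3cc(F)cc(F)c3)c(=O)c3ccc(N(C)C)nc32)c1` is not yet measured; it relates to compound 2 as compound 3 relates to compound 1, by the same change, (a group of 6 heavy atoms (5 carbon, 1 nitrogen; one six-membered aromatic ring with 1 hetero atom) in place of a group of 7 heavy atoms (6 carbon, 1 nitrogen; one six-membered non-aromatic ring with 1 hetero atom), on a saturated chain carbon, seven bonds along the chain from an oxygen on an aromatic ring). Because the measured step was a number 0.6 percentage points higher from compound 1 to compound 3 (within the scatter), the step to compound 4 is expected to be similar, estimated as a number 0.7 percentage points lower from compound 2 to compound 4 (within the scatter), which rests on that one earlier pair alone. The estimate for compound 4 in this assay is 79%, with an expected range from 62% to 92%.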

Compound 4, a percentage reported as inhibition, at one concentration (the size of the read-out at that concentration, not a potency): 61%
Compound 4: the middle estimate sits 18 percentage points above what was measured; the measured number lies below the stated range.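

In this assay, placing the six-membered aromatic ring in place of the six-membered non-aromatic ring at the charged end of the chain gives a number 18.7 percentage points lower from compound 2 to compound 4 (beyond the scatter). Within the data shown here, the same change therefore does not carry over with the same size from one core to the other: the same change on two cores in this assay, a number 0.6 percentage points higher (within the scatter) from compound 1 to compound 3 and a number 18.7 percentage points lower (beyond the scatter) from compound 2 to compound 4, 19.3 percentage points apart, beyond the scatter of two such steps This shows that, across these two pairs, the size of the step depends on the core that carries the change, but with only two cores it does not show which part of the core is responsible, or how the change would behave on any further core.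

The compounds shown leave open whether another charged end group, such as a trimethylammonium, or an uncharged tertiary amine would behave on the two cores as this change does. They also leave open whether a shorter or a longer chain would widen or narrow the gap between the two steps.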